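Series notes: aryl change on an aromatic nitrogen

The compounds below may be only part of what the source reports. "The series", "measured", "known", "first", "only" and "open" are said of these compounds alone.

Compound 1 `Cc1cccc(-n2nncc2CN2C(=O)C3(C(C#N)=C(N)Oc4c3c3nc5ccccc5nc3c3ccccc43)c3ccccc32)c1`: > 50000 nM
Compound 2 `N#CC1=C(N)Oc2c(c3nc4ccccc4nc3c3ccccc23)C12C(=O)N(Cc1cnnn1-c1ccc(Cl)c(Cl)c1)c1ccccc12`: > 50000 nM
Compound 3 `Cc1ccccc1-n1nncc1CN1C(=O)C2(C(C#N)=C(N)Oc3c(N)cc4nc5ccccc5nc4c32)c2ccccc21`: > 50000 nM

All three values in an ADME assay on L02 cells (Homo sapiens) for antiproliferative activity, read by MTT assay, with a stated time of 48 h (a higher number here means a weaker inhibitor, a lower number a stronger inhibitor), are limits of the assay, not numbers. Compound 3 stands at that limit, as do the other two, so nothing ranks it against them. For the measured compounds named here, the step that the two limits leave unreadable from compound 1 to compound 2 is unreadable, both of its ends being limits; the only evidence is the limit of > 50000 nM in this assay, at which 3 of the 3 values shown sit, with every value sitting there. Compound 4 `COc1ccc(-n2nncc2CN2C(=O)C3(C(C#N)=C(N)Oc4c(N)cc5nc6ccccc6nc5c43)c3ccccc32)cc1` differs from compound 3 by 4-methoxyphenyl in place of 2-methylphenyl on an aromatic nitrogen. Going by the values given here, no measured step bears on this change, and none of the measured steps is readable. The step that the limit leaves unreadable from compound 3 to compound 4 is therefore expected to be none beyond the scatter, with the assay most likely again reporting only a limit. Compound 4 is expected at 80000 nM, within 40000 nM to 200000 nM.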

Compound 4, half-maximal inhibitory concentration: > 50000 nM
Compound 4: no number, only a limit; the forecaster's own chance of this, stated with the estimate: 85%; the middle value does not contradict the limit.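

In this assay, for the compounds shown here, compound 3 and compound 4 both give only a limit, not a number, so no step between them can be read. In this assay the compounds shown leave open how they rank and whether any aryl change on the aromatic nitrogen shifts the value.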